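A few compounds are considered here, and "the series" means these few. Any claim that something is new, unique, unknown or untested is made for them only; others in the source may bear on it.

Compound 1 `CC1=CSC2=NC(/C=C/c3ccc(Cl)cc3)=C(C(=O)/C=C/c3ccc(Cl)cc3)C(c3ccccc3)N12` was tested in an ADME assay on Vero cells (Chlorocebus sabaeus) for cytotoxicity, read by fluorescence and resazurin assay, with a stated time of 72 h (on this read-out lower numbers stand for higher toxicity in this test and higher numbers for lower toxicity in this test), and gives 252 ug/mL. Compound 2 `COc1ccc(C2C(C(=O)/C=C/c3ccc(Cl)cc3)=C(/C=C/c3ccc(Cl)cc3)N=C3SC=C(C)N32)cc1` carries a methoxy group in place of a hydrogen on one aromatic carbon, and in this assay compound 2 gives 273 ug/mL. The step of a 1.1-fold higher number from compound 1 to compound 2 (0.03 log units; within the scatter) shows that the two measured numbers sit together within the scatter, so compound 2 stands at a number no different from that of compound 1.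

Compound 3 `CC1=CSC2=NC(/C=C/c3ccc(Cl)cc3)=C(C(=O)/C=C/c3ccc(Cl)cc3)C(c3ccc(Cl)cc3)N12` is not yet measured. It differs from compound 2 in one place: chloro in place of methoxy on an aromatic carbon. Going by the values given here, the only measured step that bears on this position, a 1.1-fold higher number from compound 1 to compound 2 (0.03 log units; within the scatter), was within the scatter, which suggests this position tolerates a change of substituent without a visible shift in this assay. Among the compounds with values here, the swap to chloro is a different change, so the evidence is thin, but nothing among the measured compounds points to a step beyond the scatter in either direction.

Compound 3 is therefore expected to give 260 ug/mL, with a range from 130 ug/mL to 520 ug/mL. The expected step is a 1.1-fold lower number from compound 2 to compound 3 (0.02 log units; within the scatter).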

Compound 3, half-maximal cytotoxic concentration: 309 ug/mL
Compound 3: the middle estimate sits 1.2-fold (0.07 log units) below what was measured; the range from low to high includes it.
By their numbers in this assay, from the lowest: compounds 1, 2 and 3 (each within the scatter of the next).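

In this assay, going from 4-methoxyphenyl to 4-chlorophenyl gives a 1.1-fold higher number from compound 2 to compound 3 (0.05 log units; within the scatter) and puts a chlorine atom where the earlier comparison had only methoxy and hydrogen, while chloro in place of hydrogen at the same place gives a 1.2-fold higher number from compound 1 to compound 3 (0.09 log units; within the scatter) as its own separate comparison. Together with the earlier step, this means that hydrogen, methoxy and chloro, three different substituents on this aromatic carbon, all lie within the scatter of one another, so the tolerance seen before is no longer tied to a single swap. Nothing available here explains why these three compounds read alike.

On these data alone, whether an amine, a carboxylic acid or a longer chain such as butoxy at this place would also stay within the scatter remains open, since three substituents say little about groups of a very different kind. Also open, as far as these compounds go, is how the read-out would respond to a change elsewhere on the shared core, which is the same in all three compounds.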